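This account rests on a few compounds, and the source may have more. Where it says the series, first, only, none or still open, it means among the compounds named here.

Values in a physicochemical assay for solubility, in phosphate buffer, with a stated time of 18 h; a higher number here means a more soluble compound, a lower number a less soluble compound:
- compound 1 `CC(C)(C)c1nc(CCCCCC#N)c2c(N)c(C#N)c(N)nc2n1`: 6000 nM
- compound 2 `CC(C)(C)c1nc(-c2ccncc2)c2c(N)c(C#N)c(N)nc2n1`: 44000 nM
- compound 3 `CC(C)(C)c1nc(-c2ncn[nH]2)c2c(N)c(C#N)c(N)nc2n1`: not yet measured

In this assay, among the compounds with values here, compound 2 gives the higher of the two numbers, and the only neighbour is compound 1 at 6000 nM. The next change is 1H-1,2,4-triazol-5-yl in place of pyridin-4-yl on an aromatic carbon. Within the data shown here, one measured step bears on it, at the same place: a 7.3-fold higher number from compound 1 to compound 2 (0.87 log units; beyond the scatter), a modest step beyond the scatter. Among the measured compounds shown here, that step brought in the pyridin-4-yl group, and no measured compound carries 1H-1,2,4-triazol-5-yl, so the direction rests on thin evidence. For the measured compounds named here, with compound 2 at 44000 nM, the top of only two numbers, a modest step down is expected, of similar size or smaller: a 2.2-fold lower number from compound 2 to compound 3 (0.34 log units; beyond the scatter). For compound 3 the estimated value is 20000 nM, with an expected range from 6000 nM to 60000 nM.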

Compound 3, solubility: 64500 nM
The estimate for compound 3 lay 3.2-fold (0.51 log units) below the measured number, and the stated range ends below it.
By their numbers in this assay, from the lowest: compound 1; then compounds 2 and 3 (each within the scatter of the next).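

In this assay, 1H-1,2,4-triazol-5-yl in place of pyridin-4-yl gives a 1.5-fold higher number from compound 2 to compound 3 (0.17 log units; within the scatter) and so does not separate the two aromatic rings at this carbon, even though the five-membered ring brings 1 hydrogen-bond donor and the six-membered ring brings none. The same triazole in place of 5-cyanopentyl gives an 11-fold higher number from compound 1 to compound 3 (1.03 log units; beyond the scatter) and thus shows that the step beyond the scatter from compound 1 is not unique to pyridin-4-yl. No measurement offered here accounts for either step.

From the compounds shown here alone, whether a saturated group such as morpholine or a simple amine would fall with compound 1 or with compounds 2 and 3 remains open. A plain hexyl chain would be needed to show whether the nitrile of 5-cyanopentyl matters to the value of compound 1.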